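The source may hold more compounds than are shown below. What is called first, only, known or untested is meant among the compounds shown, and "the series" means these compounds.

Working notes on the series. The shared core is carried by compound 1 `C=CC(=O)Nc1cccc(NC(=O)CSc2nc(Nc3ccccc3Br)c3ccccc3n2)c1`, compound 2 `C=CC(=O)Nc1cccc(NC(=O)CSc2nc(Nc3cccc(F)c3)c3ccccc3n2)c1` and compound 3 `C=CC(=O)Nc1cccc(NC(=O)CSc2nc(Nc3cccc([N+](=O)[O-])c3)c3ccccc3n2)c1`. In a functional assay on MGC-803 cells (Homo sapiens) for inhibition, read by MTT assay, with a stated time of 72 h (on this read-out higher numbers stand for weaker inhibition and lower numbers for stronger inhibition), compound 1 gives 12800 nM and compound 2 gives 6250 nM. Compound 3 gives > 50000 nM, which is the limit of > 50000 nM in this assay, at which 1 of the 3 values shown sits, and not a number. Compound 4 `C=CC(=O)Nc1cccc(NC(=O)CSc2nc(Nc3ccc(C(F)(F)F)cc3)c3ccccc3n2)c1` differs from compound 3 by 4-(trifluoromethyl)phenyl in place of 3-nitrophenyl on a nitrogen on an aromatic ring. Among the measured compounds shown here, the steps measured on this nitrogen are a 2.0-fold lower number from compound 1 to compound 2 (0.31 log units; beyond the scatter), an at least 3.9-fold higher number from compound 1 to compound 3 (0.59 log units; beyond the scatter) and an at least 8.0-fold higher number from compound 2 to compound 3 (0.90 log units; beyond the scatter); none of them touches a trifluoromethyl group or the 4-(trifluoromethyl)phenyl, so they show only that the 3-nitrophenyl of compound 3 sits at the weak end. Compound 4 is therefore expected to return a number, with an expected step of an at least 4.1-fold lower number from compound 3 to compound 4 (0.61 log units; beyond the scatter). Compound 4 is estimated at 12000 nM, in the range 3000 nM to 50000 nM.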

Compound 4, half-maximal inhibitory concentration: 12100 nM
Beside the measured number, compound 4's estimate is 1.0-fold (0.00 log units) below it; the range from low to high includes it.
By their numbers in this assay, from the lowest: compounds 2, 4 and 1 (each within the scatter of the next, the first and the last beyond it). At a limit, above all of these: compound 3.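

In this assay, 4-(trifluoromethyl)phenyl on this nitrogen gives a number where 3-nitrophenyl gives only a limit, with an at least 4.1-fold lower number from compound 3 to compound 4 (0.61 log units; beyond the scatter). The new group is not separated from the two earlier halogen-bearing phenyl groups, with a 1.9-fold higher number from compound 2 to compound 4 (0.29 log units; within the scatter) and a 1.1-fold lower number from compound 1 to compound 4 (0.02 log units; within the scatter), both within the scatter. The value of compound 3 remains a limit and not a number: the limit of > 50000 nM in this assay, at which 1 of the 4 values shown sits.

The compounds shown leave open how the unsubstituted phenyl would read on this nitrogen. They also leave open whether an amine or a carboxylic acid on the phenyl ring would read closer to compound 3 or to compound 4.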